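The source may report more compounds than this note shows. Statements on the series, on what has been measured and on what is new or still open speak of the compounds shown alone.

In a functional assay on PC-3 cells (Homo sapiens) for antiproliferative activity, read by CCK-8 assay, with a stated time of 6 days (on this read-out higher numbers stand for weaker inhibition and lower numbers for stronger inhibition), three compounds are shown. Compound 1 `N#Cc1ccc(N2CCc3cc(-c4cnc5ccccc5c4)ccc3C2)cc1C(F)(F)F` gives 25100 nM. For compound 2 `Cc1noc(C)c1-c1cccc(Oc2ccc(C#N)c(C(F)(F)F)c2)c1` the result in this assay is "not determined" (no result reported). Compound 3 `CCN(c1ccc(C#N)c(Cl)c1)c1cc(-c2cccs2)ccc1C` reaches only the limit of this assay, > 30000 nM. Compound 3 therefore stands at the weak end of what has been measured, the position described by the limit of > 30000 nM in this assay, at which 1 of the 3 values shown sits. Compound 4 `CCN(c1ccc(C#N)c(Cl)c1)c1cc(-c2ccoc2)ccc1C` differs from compound 3 by furan-3-yl in place of thiophen-2-yl on an aromatic carbon. For the measured compounds named here, no step between measured compounds covers this change. The expected step of a number no higher from compound 3 to compound 4 (the limit leaves the size open) lies within the usual scatter, in no firm direction. Compound 4 is estimated at 30000 nM in this assay, with a range from 10000 nM to 100000 nM, and a strong chance that only a limit is again reported.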

Compound 4, half-maximal inhibitory concentration: > 30000 nM
Compound 4: no number, only a limit; the forecaster's own chance of this, stated with the estimate: 70%; the middle value sits exactly at the limit.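

Compound 3 and compound 4 both stand only at a limit, so no step can be read between them: the limit of > 30000 nM in this assay, at which 2 of the 4 values shown sit. The compounds shown leave open how furan-3-yl and thiophen-2-yl truly compare in this assay.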